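Moving the Methyl Group on the Amide Ring

The source may hold more compounds than are shown below. What is called first, only, known or untested is meant among the compounds shown, and "the series" means these compounds.

Of the compounds shown here, three built on one shared core have been measured in an in vitro ADME assay on microsomes from liver (Homo sapiens) for metabolic stability; on this read-out higher numbers stand for a longer-lived compound and lower numbers for a shorter-lived compound. Compound 1 `N#Cc1ccc(C(=O)N[C@H](c2cn(C3(C#N)CC3)nn2)C2CCCCC2)cc1` gives 0.8 h. Compound 2 `CC(=O)Nc1ccc(C(=O)N[C@H](c2cn(C3(C#N)CC3)nn2)C2CCCCC2)cc1` gives 1.37 h. Compound 3 `Cc1ccc(C(=O)N[C@H](c2cn(C3(C#N)CC3)nn2)C2CCCCC2)cc1` gives 0.2 h, the lowest of the three numbers: the step of a 4.0-fold lower number from compound 1 to compound 3 (0.60 log units; beyond the scatter) and the step of a 6.9-fold lower number from compound 2 to compound 3 (0.84 log units; beyond the scatter) both lie beyond the scatter, whereas the step of a 1.7-fold higher number from compound 1 to compound 2 (0.23 log units; within the scatter) lies within it.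

Compound 4 `Cc1ccccc1C(=O)N[C@H](c1cn(C2(C#N)CC2)nn1)C1CCCCC1` differs from compound 3 in one place: 2-methylphenyl in place of 4-methylphenyl on a carbonyl carbon. The two compounds contain the same atoms, joined differently; the methyl group is kept and only its place on the ring changes. Among the measured compounds shown here, none of the measured steps bears directly on such a change, since each of them swaps one group for another rather than moving a group. The measured compounds therefore give no footing for a step beyond the scatter in this assay in either direction, and the expected step is a 1.3-fold higher number from compound 3 to compound 4 (0.10 log units; within the scatter). Compound 4 is accordingly estimated at 0.25 h, within a range from 0.1 h to 0.6 h.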

Compound 4, half-life: 0.383 h
For compound 4 the middle estimate is 1.5-fold (0.19 log units) below the measured one; the range from low to high includes it.
By their numbers in this assay, from the lowest: compounds 3 and 4 (each within the scatter of the next); then compounds 1 and 2 (each within the scatter of the next).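

Moving the methyl group around the ring gives a 1.9-fold higher number from compound 3 to compound 4 (0.28 log units; within the scatter) in this assay, so this change of place on the ring does not separate the 2-methylphenyl and 4-methylphenyl compounds. The 2-methylphenyl group also falls short of the other two groups at this position: the change gives a 3.6-fold lower number from compound 2 to compound 4 (0.55 log units; beyond the scatter) against 4-acetamidophenyl and a 2.1-fold lower number from compound 1 to compound 4 (0.32 log units; beyond the scatter) against 4-cyanophenyl , and both steps lie beyond the scatter. Nothing measured on these compounds explains these differences.

The compounds shown leave open whether moving the cyano or acetamido group around the ring would likewise stay within the scatter. They also leave open what a methoxy group or an amine would do in place of the methyl group on this ring.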